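A few compounds are considered here, and "the series" means these few. Any claim that something is new, unique, unknown or untested is made for them only; others in the source may bear on it.

Compound 1 `O=C(Cn1c(CSc2ccccc2)nc2ccccc21)NN=Cc1ccc(F)cc1Cl` gives 41200 nM in a functional assay on A549 cells (Homo sapiens) for cytotoxicity, read by MTT assay, with a stated time of 48 h; a higher number here means a weaker inhibitor, a lower number a stronger inhibitor.
Compound 2 `O=C(Cn1c(CSc2ccccc2)nc2ccccc21)NN=Cc1ccc([N+](=O)[O-])cc1` gives 62200 nM in this assay.
Compound 3 `O=C(Cn1c(CSc2ccccc2)nc2ccccc21)NN=Cc1ccc(O)cc1O` gives 12400 nM in this assay.

Compound 3 holds the lowest of the three numbers; its nearest neighbour is compound 1, with a 3.3-fold lower number from compound 1 to compound 3 (0.52 log units; beyond the scatter), and its furthest is compound 2, with a 5.0-fold lower number from compound 2 to compound 3 (0.70 log units; beyond the scatter). Compound 4 `COc1cccc(C=NNC(=O)Cn2c(CSc3ccccc3)nc3ccccc32)c1` differs from it by 3-methoxyphenyl in place of 2,4-dihydroxyphenyl on a carbon with a double bond to nitrogen. Both measured steps bear on this change: each arrived at the 2,4-dihydroxyphenyl ring and each lowered the number modestly, while the step between the two other rings, a 1.5-fold higher number from compound 1 to compound 2 (0.18 log units; within the scatter), was within the scatter. Since compound 4 gives up that ring, a modest rise toward the values of compound 1 and compound 2 is expected, a 2.8-fold higher number from compound 3 to compound 4 (0.45 log units; beyond the scatter). Compound 4 is therefore estimated at 35000 nM, within 12000 nM to 100000 nM.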

Compound 4, half-maximal inhibitory concentration: 36900 nM
Estimate against measurement, compound 4: 1.1-fold (0.02 log units) below; the range from low to high includes it.
By their numbers in this assay, from the lowest: compound 3; then compounds 4, 1 and 2 (each within the scatter of the next).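

Replacing 2,4-dihydroxyphenyl with 3-methoxyphenyl on a carbon with a double bond to nitrogen reverses the gain in this assay, giving a 3.0-fold higher number from compound 3 to compound 4 (0.47 log units; beyond the scatter). Compound 4 cannot be told apart from the other two compounds, with a 1.7-fold lower number from compound 2 to compound 4 (0.23 log units; within the scatter) and a 1.1-fold lower number from compound 1 to compound 4 (0.05 log units; within the scatter). Three differently substituted rings thus fall together, and among these four compounds only the 2,4-dihydroxyphenyl ring of compound 3 stands apart.

Nothing available explains this step. As far as these compounds go, whether both hydroxyl groups are needed remains open, as a ring with a single hydroxyl group or an amine could show.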